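The source may hold more compounds than are shown below. What is called first, only, known or untested is meant among the compounds shown, and "the series" means these compounds.

Measured in a functional assay on PC-3 cells (Homo sapiens) for cytotoxicity, read by WST assay, with a stated time of 72 h; on this read-out higher numbers stand for weaker inhibition and lower numbers for stronger inhibition:
- compound 1 `COc1ccc(C2(c3ccc(O)cc3)C(=O)Nc3c2ccc(F)c3F)cc1`: 2 nM; 2.2 nM; > 1000 nM (3 entries)
- compound 2 `CCCC1(c2ccc(O)cc2)C(=O)Nc2c1ccc(F)c2F`: > 1000 nM
- compound 3 `CCCCCC1(c2ccc(O)cc2)C(=O)Nc2c1ccc(F)c2F`: 1.1 nM

Among the compounds with values here, compound 3, at 1.1 nM, holds the only single number in this set. The entry for compound 2, > 1000 nM, is a limit of the assay. The entries for compound 1 do not agree, and one of them is also a limit: the several entries of compound 1 in this assay, 2 nM; 2.2 nM; > 1000 nM (3 entries).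

The open step leads to compound 4 `O=C1Nc2c(ccc(F)c2F)C1(c1ccc(O)cc1)C1CCCCCC1`: cycloheptyl in place of pentyl on a saturated ring carbon. Within the data shown here, the one measured step, an at least 900-fold lower number from compound 2 to compound 3 (2.95 log units; beyond the scatter), concerns the chain on this same saturated ring carbon and is large, so the group here can move the read-out sharply. Compound 1 also carries a ring on that carbon, and two of its entries are low numbers (the several entries of compound 1 in this assay, 2 nM; 2.2 nM; > 1000 nM (3 entries)), which suggests a ring may be accepted there. No step beyond the scatter is therefore expected in this assay, though a weaker result remains possible. The estimated step is a 1.8-fold higher number from compound 3 to compound 4 (0.26 log units; within the scatter). For compound 4 the expected value is 2 nM, with an estimated range of 0.5 nM to 20 nM.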

Compound 4, half-maximal inhibitory concentration: 12 nM
Compound 4: the middle estimate sits 6.0-fold (0.78 log units) below what was measured; low and high end bracket the measured number.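

In this assay, cycloheptyl on the saturated ring carbon does not match pentyl, with an 11-fold higher number from compound 3 to compound 4 (1.04 log units; beyond the scatter), so a low number here is not kept on every exchange of pentyl for a larger group. Cycloheptyl still stands well apart from the shorter chain, with an at least 83-fold lower number from compound 2 to compound 4 (1.92 log units; beyond the scatter), which shows that a saturated carbon ring on this carbon can retain strong inhibition. For compound 2, > 1000 nM is a limit of the assay, so that step gives only a minimum size.

As far as these compounds go, whether an aromatic ring is as well accepted on this carbon stays unsettled, since compound 1 gives no single reading: the several entries of compound 1 in this assay, 2 nM; 2.2 nM; > 1000 nM (3 entries) How cyclopentyl, cyclohexyl or a hexyl chain would stand at this carbon remains open, and with it whether the loss from pentyl to cycloheptyl follows from the ring or from its size.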